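The compounds below may be only part of what the source reports. "The series", "measured", "known", "first", "only" and "open" are said of these compounds alone.

Compound 1 `CCOc1cc(C(=O)N(C)C)nn1-c1ccccc1` gives 65.8% in a functional assay on the whole organism (strain Wistar) for inhibition, with Rattus norvegicus as the target, read by paw edema, with stated times of 30 min and 3 h, at a dose of 100 mg/kg by the oral route; on this read-out higher numbers stand for more inhibition at the one dose given (going by the name of the read-out) and lower numbers for less inhibition.
Compound 2 `CCCOc1cc(C(=O)N(C)C)nn1-c1ccccc1` gives 26.2% in this assay.
Compound 3 `CCCCOc1cc(C(=O)N(C)C)nn1-c1ccccc1` gives 18.7% in this assay.

Compound 3 has the lowest number of the three; the gap to compound 2 lies within the scatter, the gap to compound 1 beyond it. Compound 4 `CC(C)CCOc1cc(C(=O)N(C)C)nn1-c1ccccc1` differs from compound 3 by methyl in place of hydrogen on a saturated chain carbon bound to two saturated chain carbons. The steps that lengthen the chain are a number 39.6 percentage points lower from compound 1 to compound 2 (beyond the scatter) and a number 47.1 percentage points lower from compound 1 to compound 3 (beyond the scatter), both large, while the step that adds one more carbon further out, a number 7.5 percentage points lower from compound 2 to compound 3 (within the scatter), lies within the scatter. The nearest analogue to the present change is that last step, so in this assay the expected step of a number 3.7 percentage points lower from compound 3 to compound 4 (within the scatter) is small, if anything downward. Compound 4 is estimated at 15%, with a range from 5% to 30%.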

Compound 4, a percentage reported as inhibition, in the whole organism at one dose (the size of the read-out at that dose, not a potency): 25.3%
Compound 4: middle estimate off by 10.3 percentage points, on the low side; the measured number falls inside the stated range.
By their numbers in this assay, from the lowest: compounds 3, 4 and 2 (each within the scatter of the next); then compound 1.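

In this assay, methyl on a saturated chain carbon bound to two saturated chain carbons changes little, a number 6.6 percentage points higher from compound 3 to compound 4 (within the scatter), and the isopentyl chain stays level with the propyl chain, a number 0.9 percentage points lower from compound 2 to compound 4 (within the scatter). The large drop seen with the unbranched chains holds for the branched chain as well, a number 40.5 percentage points lower from compound 1 to compound 4 (beyond the scatter), which places compounds 2, 3 and 4 together in one low band. Adding a methyl to this chain therefore has no fixed effect across the series: the same change on two cores in this assay, a number 39.6 percentage points lower (beyond the scatter) from compound 1 to compound 2 and a number 6.6 percentage points higher (within the scatter) from compound 3 to compound 4, 46.2 percentage points apart, beyond the scatter of two such steps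

On these data alone, it remains open how a shorter methoxy group would compare with compound 1. Also open, as far as these compounds go, is whether a chain ending in an amine or a carboxylic acid would stay in the low band.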